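The source may hold more compounds than are shown below. What is called first, only, known or untested is meant among the compounds shown, and "the series" means these compounds.

Measured compounds:
compound 1, `CC1=C(C(=O)NC(C)C)C(c2cccs2)NC(=O)N1`, giving 1% in an assay on membranes from HeLa cells for displacement of a labelled ligand from adenosine receptor A3 (Homo sapiens), read by scintillation counting, with a stated time of 180 min, tested at 1 uM; on this read-out lower numbers stand for less inhibition and higher numbers for more inhibition at the one concentration tested (going by the name of the read-out).
compound 2, `CC1=C(C(=O)NC(C)C)C(c2ccsc2)NC(=O)N1`, giving 1% in this assay.

In this assay compound 1 gives 1% and compound 2 gives 1%. The one measured step, no change at the digits printed from compound 1 to compound 2 (within the scatter), is within the scatter, so compound 2 stands level with compound 1 at the digits shown, and neither compound shows inhibition worth noting at the concentration tested.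

Compound 3, `CC1=C(C(=O)OCC2CC2)C(c2ccsc2)NC(=O)N1`, has not yet been measured. It differs from compound 2 as follows: cyclopropylmethoxy in place of isopropylamino on a carbonyl carbon. Within the data shown here, no measured step bears on this change; the only step in hand, no change at the digits printed from compound 1 to compound 2 (within the scatter), concerns the thiophene and is within the scatter. What the data show is that the shared core with the isopropylamino amide sits at the bottom of the read-out in this assay regardless of the thiophene attachment. Without any step touching the carbonyl substituent, the expectation for compound 3 rests on that low baseline. Compound 3 is expected to stay near the same level, a step of about a number 2 percentage points higher from compound 2 to compound 3 (within the scatter). The estimate for compound 3 in this assay is 3%, within 0% to 15%.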

Compound 3, a percentage reported as inhibition, at one concentration (the size of the read-out at that concentration, not a potency): 3%
Compound 3: middle estimate and measured number agree at the digits printed, and the stated range covers the measured number.
By their numbers in this assay, from the lowest: compounds 1, 2 and 3 (each within the scatter of the next).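

In this assay, among these compounds, the carbonyl carbon, whose other neighbour is the double-bonded ring carbon, is varied for the first time, and replacing isopropylamino with cyclopropylmethoxy gives a number 2 percentage points higher from compound 2 to compound 3 (within the scatter). This exchange removes the hydrogen-bond donor counted on isopropylamino and brings in a hydrogen-bond acceptor and a three-membered ring, yet the result stays within the scatter, so at the one concentration tested the read-out does not separate these two groups, just as it did not separate the two thiophene attachments. No measurement on hand explains this result.

All three compounds sit so low in the read-out that the compounds shown leave open whether any group on this carbonyl carbon can produce clear inhibition, for example a benzyloxy group, a longer chain such as n-hexyloxy, or a carboxylic acid. They also leave open whether cyclopropylmethoxy would behave the same way with thiophen-2-yl on the saturated ring carbon, a pairing that none of the compounds shown carries.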